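The source may hold more compounds than are shown below. What is called first, only, known or untested is meant among the compounds shown, and "the series" means these compounds.

Compound 1 `CC(C)n1ncc2c(C(=O)Nc3cccc(C(N)=O)c3)cc(-c3cccs3)nc21`: 25000 nM
Compound 2 `CC(C)n1ncc2c(C(=O)Nc3ccccn3)cc(C3CC3)nc21`: 25000 nM
Compound 3 `CC(C)n1ncc2c(NC(=O)c3ccc(F)cc3)cc(-c3cccs3)nc21`: 50000 nM

All three compounds were tested in an ADME assay on LLC-MK2 cells (Macaca mulatta) for cytotoxicity, read by spectrophotometry and crystal violet staining, with a stated time of 4 days; on this read-out lower numbers stand for higher toxicity in this test and higher numbers for lower toxicity in this test. Compound 2 gives 25000 nM, the same number as compound 1 at 25000 nM. Compound 3 gives 50000 nM, but this difference stays within the usual scatter of repeated measurements, so the three numbers cannot be put in order.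

Compound 4 `CC(C)n1ncc2c(C(=O)Nc3ccccn3)cc(-c3ccsc3)nc21` has not yet been measured. It differs from compound 2 in one place: thiophen-3-yl in place of cyclopropyl on an aromatic carbon. Thiophen-3-yl stands in place of cyclopropyl on an aromatic carbon, next to the ring nitrogen.

Within the data shown here, no two measured compounds differ in only one place, so the data do not show the effect of this swap directly. Compound 1 at 25000 nM and compound 3 at 50000 nM both carry a sulfur-containing five-membered aromatic ring, although they differ from compound 4 elsewhere. Their numbers sit within the scatter of compound 2, so no step beyond the scatter is expected in this assay, and neither direction is clearly favoured. The estimated step of a 1.2-fold higher number from compound 2 to compound 4 (0.08 log units; within the scatter) is therefore small. For compound 4 the expected value is 30000 nM, with an estimated range of 12000 nM to 70000 nM.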

Compound 4, half-maximal cytotoxic concentration: 25000 nM
Estimate against measurement, compound 4: 1.2-fold (0.08 log units) above; the measured number falls inside the stated range.
By their numbers in this assay, from the lowest: compounds 1, 2, 4 and 3 (each within the scatter of the next).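

In this assay, among these compounds, this pair gives the first direct look at a single change on the shared core: no change at the digits printed from compound 2 to compound 4 (within the scatter). On an aromatic carbon next to the ring nitrogen, a three-membered non-aromatic ring of carbon only gives way to thiophen-3-yl, a five-membered aromatic ring with 1 hetero atom, and the number does not move. The earlier compounds could only hint at this, since each differed from the others in more than one place, whereas here the comparison is clean, though it rests on this one pair, and nothing measured here offers an explanation for the result.

As far as these compounds go, what this assay would show with a different kind of group at this position, such as an amine, a carboxylic acid or a longer chain, remains open. Also unknown is whether the same swap would leave the number unchanged on a compound with something other than the pyridine-bearing amide of compound 2 and compound 4, since no such pair is shown.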